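Thiophene swap to methylcyclopentene on the chloro compound

The compounds below may be only part of what the source reports. "The series", "measured", "known", "first", "only" and "open" are said of these compounds alone.

compound 1 `Clc1ccc(Nc2nccs2)cc1OCc1cccs1`: 38000 nM
compound 2 `Clc1ccc(Nc2nccs2)cc1OCc1ccsc1`: 38000 nM
compound 3 `N#Cc1ccc(Nc2nccs2)cc1OCc1ccsc1`: 1100 nM

In a functional assay on MT2 cells (Homo sapiens) for cytotoxicity, read by MTT assay (a lower number here means that less compound is tolerated, a higher number that more compound is tolerated), compound 1 and compound 2 share the highest of the three numbers, with compound 2 at 38000 nM. Compound 3 holds the lowest number at 1100 nM.

The next change leads to compound 4 `CC1=C(COc2cc(Nc3nccs3)ccc2Cl)CCC1`: 2-methylcyclopent-1-en-1-yl in place of thiophen-3-yl on a saturated chain carbon bound to an oxygen on an aromatic ring. In words, 2-methylcyclopent-1-en-1-yl stands in place of thiophen-3-yl on a saturated chain carbon bound to an oxygen on an aromatic ring.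

Going by the values given here, two measured steps bear on this. The closer one is no change at the digits printed from compound 1 to compound 2 (within the scatter), made at the same place. The other is a 35-fold lower number from compound 2 to compound 3 (1.54 log units; beyond the scatter), but it comes from cyano in place of chloro on an aromatic carbon, and compound 4 keeps the chloro. Among the compounds with values here, no measured compound carries a non-aromatic ring at this place, so the evidence is thin.

Going by the step of no change at the digits printed from compound 1 to compound 2 (within the scatter), no step beyond the scatter is expected in this assay. The estimated step is a 1.2-fold lower number from compound 2 to compound 4 (0.07 log units; within the scatter). For compound 4 the expected value is 32000 nM, with an estimated range of 13000 nM to 70000 nM.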

Compound 4, half-maximal cytotoxic concentration: 11000 nM
For compound 4 the middle estimate is 2.9-fold (0.46 log units) above the measured one; measured number below the stated range.
By their numbers in this assay, from the lowest: compound 3; then compound 4; then compounds 1 and 2 (each within the scatter of the next).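

In this assay, going by these compounds alone, the two thiophene isomers on the saturated chain carbon bound to an oxygen on an aromatic ring gave no separation, so the earlier compounds showed no response at this position. The non-aromatic ring now separates from both, with a 3.5-fold lower number from compound 2 to compound 4 (0.54 log units; beyond the scatter) and a 3.5-fold lower number from compound 1 to compound 4 (0.54 log units; beyond the scatter), so the group held here does register, though the step is modest and rests on the chloro compounds alone. No measurement available here accounts for this step.

The change swaps the aromatic ring for a non-aromatic one, removes the sulfur and adds a methyl at once, and these cannot be told apart here. Also open, going by these compounds, are how a plain cyclopentyl ring, a phenyl ring or an amine would read at this place, and whether the step carries over to the cyano compound 3.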